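Swapping a Halogen for a Nitro Group on the Pendant Ring

The source may hold more compounds than are shown below. What is called first, only, known or untested is meant among the compounds shown, and "the series" means these compounds.

Within the data shown here, in a functional assay on MKN-45 cells (Homo sapiens) for cytotoxicity, read by MTT assay, with a stated time of 72 h (a lower number here means a stronger inhibitor, a higher number a weaker inhibitor), compound 2 `COc1cc2c(Oc3ccc(NC(=O)c4nn(-c5ccccc5Br)c(=O)c5ccccc45)cc3F)ccnc2cc1OCCCN1CCC(C)CC1` gives 510 nM, and compound 1 `COc1cc2c(Oc3ccc(NC(=O)c4nn(-c5ccccc5F)c(=O)c5ccccc45)cc3F)ccnc2cc1OCCCN1CCC(C)CC1` gives 260 nM; the two numbers sit within the scatter of each other, as the only measured step, a 2.0-fold higher number from compound 1 to compound 2 (0.29 log units; within the scatter), shows. Compound 3 `COc1cc2c(Oc3ccc(NC(=O)c4nn(-c5ccc([N+](=O)[O-])cc5)c(=O)c5ccccc45)cc3F)ccnc2cc1OCCCN1CCC(C)CC1` differs from compound 2 by 4-nitrophenyl in place of 2-bromophenyl on an aromatic nitrogen. Among the measured compounds shown here, no measured step involves a nitro group, so that single halogen swap is the only guide, and it suggests a change on this pendant ring moves the number little. Compound 3 is therefore expected to give 500 nM, within 200 nM to 1250 nM. That estimate means a step of a 1.0-fold lower number from compound 2 to compound 3 (0.01 log units; within the scatter), expected to stay within the scatter.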

Compound 3, half-maximal inhibitory concentration: 1150 nM
The estimate for compound 3 lay 2.3-fold (0.36 log units) below the measured number; the range from low to high includes it.
By their numbers in this assay, from the lowest: compounds 1 and 2 (each within the scatter of the next); then compound 3.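

Both a 2.3-fold higher number from compound 2 to compound 3 (0.35 log units; beyond the scatter) and a 4.4-fold higher number from compound 1 to compound 3 (0.65 log units; beyond the scatter) lie beyond the scatter, so the group on this pendant ring can shift the number, which the halogen swap alone did not reveal. The direction here is toward weaker inhibition, with 4-nitrophenyl behind both 2-halophenyl groups. Nothing available explains this rise. The compounds shown leave open whether the nitro group or its place on the ring matters, since the two change together. From the compounds shown here alone, how an amine or a carboxylic acid on this ring would compare also remains open.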